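A few compounds are considered here, and "the series" means these few. Any claim that something is new, unique, unknown or untested is made for them only; others in the source may bear on it.

Compound 1 `CC1=C(C(=O)C2CC2)C(c2ccoc2)NC(=O)N1` gives 16% in an assay on membranes from HeLa cells for displacement of a labelled ligand from adenosine receptor A3 (Homo sapiens), read by scintillation counting, with a stated time of 180 min, tested at 1 uM; a higher number here means more inhibition at the concentration tested (going by the name of the read-out), a lower number less inhibition.
Compound 2 `CC1=C(C(=O)C2CC2)C(c2cccs2)NC(=O)N1` gives 15% in this assay.

Compound 1 stands highest of the two numbers, but its nearest neighbour is compound 2, with a number 1 percentage points lower from compound 1 to compound 2 (within the scatter), so the two cannot be told apart. Compound 3 `CC1=C(C(=O)NC(C)C)C(c2ccoc2)NC(=O)N1` has not been measured. Its change from compound 1 is isopropylamino in place of cyclopropyl on a carbonyl carbon: cyclopropyl leaves and isopropylamino enters on a carbonyl carbon whose other neighbour is a double-bonded ring carbon. For the measured compounds named here, no measured step touches this carbonyl carbon; the only step in hand, from compound 1 to compound 2, alters a different position and is within the scatter, so it offers no guide to the size or direction of the new change. With both measured compounds close together near the low end, compound 3 is expected to show a number 4 percentage points lower from compound 1 to compound 3 (within the scatter). Compound 3 is therefore estimated at 12%, with a range from 0% to 35%.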

Compound 3, a percentage reported as inhibition, at one concentration (the size of the read-out at that concentration, not a potency): 3%
The estimate for compound 3 lay 9 percentage points above the measured number, and the stated range covers the measured number.
By their numbers in this assay, from the lowest: compound 3; then compounds 2 and 1 (each within the scatter of the next).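

At the carbonyl carbon, which the earlier pair left untouched, isopropylamino in place of cyclopropyl gives a number 13 percentage points lower from compound 1 to compound 3 (beyond the scatter) in this assay. This is the first step among these compounds to lie beyond the scatter, so this position registers a change where the swap of furan-3-yl for thiophen-2-yl did not. Nothing available here explains the lower number.

The change from cyclopropylcarbonyl to isopropylcarbamoyl removes a ring and adds a nitrogen with a hydrogen-bond donor in a single step, so the compounds shown cannot assign the lower number to either alteration. From the compounds shown here alone, a cyclopropylamino group on the same carbonyl carbon would keep the ring while adding the nitrogen, and it remains open how such a compound would read.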